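The source may report more compounds than this note shows. Statements on the series, on what has been measured and on what is new or still open speak of the compounds shown alone.

Measured so far:
Compound 1 `CC1=CC[C@@H]([C@@](C)(O)CCCC(C)(C)NC(=S)N/N=C\c2ccc(C)cc2)CC1` gives 6510 nM in a functional assay on NCI/ADR cells (Homo sapiens) for cytotoxicity, read by sulforhodamine B assay; a lower number here means a stronger inhibitor of growth, a higher number a weaker inhibitor of growth.
Compound 2 `CC1=CC[C@@H]([C@@](C)(O)CCCC(C)(C)NC(=S)N/N=C\c2cccc(Cl)c2)CC1` gives 7350 nM in this assay.

Of these two numbers compound 2 has the higher one, but the step of a 1.1-fold higher number from compound 1 to compound 2 (0.05 log units; within the scatter) lies within the scatter, so the two compounds cannot be told apart. Compound 3 `CC1=CC[C@@H]([C@@](C)(O)CCCC(C)(C)NC(=S)N/N=C(/C)c2ccccc2)CC1` differs from compound 2 by a group of 9 heavy atoms (8 carbon, 1 nitrogen; one six-membered aromatic ring of carbon only) in place of a group of 9 heavy atoms (7 carbon, 1 nitrogen, 1 chlorine; one six-membered aromatic ring of carbon only), on an amide-type nitrogen. Among the compounds with values here, the only measured step, which exchanged one aryl group for another on the carbon with the double bond to nitrogen, stayed within the scatter, and the present change again reshapes the group on that nitrogen, so the expected step is no more than the scatter, a 1.1-fold lower number from compound 2 to compound 3 (0.02 log units; within the scatter). For compound 3 in this assay the expected value is 7000 nM, with a range from 3000 nM to 16000 nM.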

Compound 3, concentration for 50% growth inhibition: 750 nM
Beside the measured number, compound 3's estimate is 9.3-fold (0.97 log units) above it, and the stated range ends above it.
By their numbers in this assay, from the lowest: compound 3; then compounds 1 and 2 (each within the scatter of the next).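

In this assay the group on the amide-type nitrogen turns out to be a sensitive place: the change gives a 9.8-fold lower number from compound 2 to compound 3 (0.99 log units; beyond the scatter), and likewise an 8.7-fold lower number from compound 1 to compound 3 (0.94 log units; beyond the scatter). Compound 1 and compound 3 carry groups with the same heavy-atom counts, so the arrangement of those atoms, rather than their number, goes with the step. Nothing measured here explains why the number falls. Still open, on these data alone, is how much of the step belongs to the extra carbon on the carbon with a double bond to nitrogen and how much to the bare aromatic ring. An ethyl group or a longer chain on that carbon would test this.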